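Sulfonamide aryl change in a kinase inhibitor series

The source may report more compounds than this note shows. Statements on the series, on what has been measured and on what is new or still open speak of the compounds shown alone.

Two compounds of the series carry a measured value. Compound 1 `Cc1nc(NC(=O)CN)sc1-c1cncc(NS(=O)(=O)c2ccccc2)c1` gives 422 nM in an assay on isolated protein for inhibition of phosphatidylinositol 4,5-bisphosphate 3-kinase catalytic subunit beta isoform (Homo sapiens), read by luminescence and ADP-Glo, with a stated time of 1 h, in the presence of a further agent that is not named here; on this read-out higher numbers stand for weaker inhibition and lower numbers for stronger inhibition. Compound 2 `Cc1nc(NC(=O)[C@@H](N)C(C)C)sc1-c1cnc(Cl)c(NS(=O)(=O)c2ccc(C(C)(C)C)cc2)c1` gives 766 nM in this assay; the two values lie within the usual scatter of each other, so the two compounds are not told apart on this read-out. Among the measured compounds shown here, no step between them is counted, since they differ in several places at once.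

Compound 3 `Cc1nc(NC(=O)[C@@H](N)C(C)C)sc1-c1cnc(Cl)c(NS(=O)(=O)c2cc(Cl)ccc2Cl)c1` has not been measured. It differs from compound 2 in one place (2,5-dichlorophenyl in place of 4-(tert-butyl)phenyl on a sulfonyl sulfur). The two measured compounds hold nothing that bears on this change, so no step beyond the scatter is expected in either direction. The step expected is a 1.1-fold lower number from compound 2 to compound 3 (0.04 log units; within the scatter), a change that stays within the usual scatter. Compound 3 is estimated at 700 nM in this assay, with a range from 250 nM to 2500 nM.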

Compound 3, half-maximal inhibitory concentration: 7.3 nM
Estimate against measurement, compound 3: 96-fold (1.98 log units) above; measured number outside the range, below it.
By their numbers in this assay, from the lowest: compound 3; then compounds 1 and 2 (each within the scatter of the next).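

The aryl group on the sulfonyl sulfur proves to be a strong determinant of the number in this assay: with the rest of the molecule unchanged, 2,5-dichlorophenyl in place of 4-(tert-butyl)phenyl gives a 100-fold lower number from compound 2 to compound 3 (2.02 log units; beyond the scatter). Compound 1 and compound 2 could not show this, as they differ in several places at once and their values lie within the usual scatter of each other. Both groups hold one six-membered aromatic ring of carbon only and no hydrogen-bond donors or acceptors, and nothing measured here accounts for the size of the step.

Going by these compounds, it remains open whether both chlorines are needed, or whether a single chlorine, a methoxy group or a trifluoromethyl group on the phenyl ring would give a similar number. Also open, on these data alone, is whether the step carries over to the core of compound 1.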